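The source may report more compounds than this note shows. Statements on the series, on what has been measured and on what is new or still open speak of the compounds shown alone.

The measured compounds:

Compound 1, `CCOC(=O)/C=C/c1cc(OC)c(OCc2nc(C)c(C)nc2C)c(OC)c1`, 2310000 nM
Compound 2, `CCOC(=O)/C=C/c1cccc(OCc2nc(C)c(C)nc2C)c1`, 4330000 nM
Compound 3, `COc1cc(/C=C/C(=O)O)cc(OC)c1OCc1nc(C)c(C)nc1C`, 3530000 nM

These three compounds were tested in a functional assay on ECV-304 cells (Homo sapiens) for cytotoxicity, read by MTT assay, with stated times of 24 h and 12 h; a lower number here means that less compound is needed, a higher number that more compound is needed for the effect. All three give numbers in the millimolar range, and none of them stands apart from the others: compound 2 has the highest number of the three, but its nearest neighbour is compound 3, and even compound 1, the furthest from it, lies within the usual scatter, so no ordering among the three can be claimed.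

Compound 1 and compound 3 share a core and differ in one place: hydrogen in place of ethyl on an oxygen next to a carbonyl group. That change gave a 1.5-fold higher number from compound 1 to compound 3 (0.18 log units; within the scatter), a step that does not rise above the scatter of repeated measurements.

Compound 4, `Cc1nc(C)c(COc2cccc(/C=C/C(=O)O)c2)nc1C`, has not yet been measured in this assay. It relates to compound 2 the way compound 3 relates to compound 1: hydrogen in place of ethyl on an oxygen next to a carbonyl group. The two "place" descriptions are identical word for word, so this is the same change made on a second core. How the core of compound 2 differs from the core of compound 1 is not broken down here.

Among the compounds with values here, because the only measured example of this change, a 1.5-fold higher number from compound 1 to compound 3 (0.18 log units; within the scatter), stayed within the scatter, compound 4 is expected to sit close to compound 2, with an estimated step of a 1.3-fold higher number from compound 2 to compound 4 (0.10 log units; within the scatter). The estimate for compound 4 in this assay is 5500000 nM, with a likely range from 2500000 nM to 12000000 nM.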

Compound 4, half-maximal effective concentration: 20000 nM
Estimate against measurement, compound 4: 280-fold (2.44 log units) above; the measured number lies below the stated range.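

In this assay, putting hydrogen in place of ethyl on an oxygen next to a carbonyl group, which turns ethoxycarbonyl into carboxy, gave a 220-fold lower number from compound 2 to compound 4 (2.34 log units; beyond the scatter), so on the core of compound 2 this change goes with a large shift in the number. Set beside the earlier step on the core of compound 1, the change did not carry from one core to the other with the same size, and the two results differ by more than repeated measurements would explain: the same change on two cores in this assay, a 1.5-fold higher number (0.18 log units; within the scatter) from compound 1 to compound 3 and a 220-fold lower number (2.34 log units; beyond the scatter) from compound 2 to compound 4, 330-fold (2.52 log units) apart, beyond the scatter of two such steps. This shows that, in these two pairs, the outcome of the change depends on the core it is made on, but it does not show which feature of the cores is responsible, why compound 4 stands apart, or what the change would do on a third core.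

The compounds shown leave open whether an amide or a methyl ester in place of the carboxy group on the core of compound 2 would give a number close to that of compound 4 or to that of compound 2. They also leave open whether the large step seen here would hold in any other read-out, since all four numbers come from this single cell assay.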